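The source may report more compounds than this note shows. Statements on the series, on what has been measured and on what is new or still open speak of the compounds shown alone.

Compound 1 `CC1CCC(=O)N1CC#CCn1ccnc1` carries a 1H-imidazol-1-yl group, and in a functional assay on the whole organism for agonist activity, with Mus musculus as the target (a lower number here means that less compound is needed, a higher number that more compound is needed for the effect), compound 1 reaches only the limit of the method, > 100 mg/kg. Compound 2 `CC1CCC(=O)N1CC#CCN(C)C` replaces that group with dimethylamino, and in this assay compound 2 gives 1.7 mg/kg. Going by these compounds, the change dimethylamino in place of 1H-imidazol-1-yl on a saturated chain carbon bound to a triple-bonded carbon thus produced an at least 58-fold lower number from compound 1 to compound 2 (1.76 log units; beyond the scatter), a step whose full size remains open since its starting point is a limit (the limit of > 100 mg/kg in this assay, at which 1 of the 3 values shown sits).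

Compound 3 `COC(=O)N(C)C(C)C#CCn1ccnc1` keeps the 1H-imidazol-1-yl group but on a different core; the difference between the core of compound 3 and the core of compound 1 is not broken down here. In this assay compound 3 gives 6.6 mg/kg. Compound 4 `COC(=O)N(C)C(C)C#CCN(C)C` differs from compound 3 by dimethylamino in place of 1H-imidazol-1-yl on a saturated chain carbon bound to a triple-bonded carbon, the same change that separates compound 1 from compound 2.

Because that change gave an at least 58-fold lower number from compound 1 to compound 2 (1.76 log units; beyond the scatter), compound 4 is expected to show a large step as well, estimated as a 22-fold lower number from compound 3 to compound 4 (1.34 log units; beyond the scatter). Since the core is not the same, the expectation carries a wide margin. Compound 4 is therefore estimated to give 0.3 mg/kg, between 0.05 mg/kg and 1.5 mg/kg.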

Compound 4, dose for half-maximal effect: 11.8 mg/kg
Compound 4: the middle estimate sits 39-fold (1.59 log units) below what was measured, and the stated range ends below it.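

On the core of compound 3, dimethylamino in place of 1H-imidazol-1-yl gives a 1.8-fold higher number from compound 3 to compound 4 (0.25 log units; within the scatter) in this assay, so this pair shows no clear effect of the change, whereas the same change gave a large step on the core of compound 1. The change therefore did not carry over from one core to the other with its size intact, and the step seen on one core cannot serve as a guide to the other: the same change on two cores in this assay, an at least 58-fold lower number (1.76 log units; beyond the scatter) from compound 1 to compound 2 and a 1.8-fold higher number (0.25 log units; within the scatter) from compound 3 to compound 4, at least 100-fold (2.02 log units) apart, beyond the scatter of two such steps

The two pairs do not show which part of the cores goes with this difference, nor how large the earlier step really is, since compound 1 is recorded only as a limit: the limit of > 100 mg/kg in this assay, at which 1 of the 4 values shown sits.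

Going by these compounds, it remains open whether a cyclic amine such as pyrrolidin-1-yl, placed on a saturated chain carbon bound to a triple-bonded carbon, would follow the pattern of the core of compound 1 or that of the core of compound 3. On these data alone, how the same change would behave with a longer chain, or on a third core, is also open.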